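The compounds below may be only part of what the source reports. "The series", "measured", "known", "first", "only" and "open" are said of these compounds alone.

Measured so far in an ADME assay on BJ cells (Homo sapiens) for cytotoxicity, with a stated time of 72 h; on this read-out higher numbers stand for an effect only at larger amounts of compound and lower numbers for an effect already at smaller amounts:
- Compound 1 `CCc1ccc(-c2nc3c(c(C)nn3-c3ccccc3)c(-c3ccccc3C#N)c2C#N)cc1`: > 20000 nM (a limit)
- Compound 2 `CCc1ccc(-c2nc3c(c(C)nn3-c3ccccc3)c(-c3ccccc3Br)c2C#N)cc1`: > 20000 nM (a limit)
- Compound 3 `CCc1ccc(-c2nc3c(c(C)nn3-c3ccccc3)c(-c3ccccc3C)c2C#N)cc1`: > 20000 nM (a limit)

Compound 3 has no numerical reading in this assay, only the limit > 20000 nM. Compound 1 and compound 2 are no different, so the whole series stands at the limit of > 20000 nM in this assay, at which 3 of the 3 values shown sit.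

Compound 4 `CCc1ccc(-c2nc3c(c(C)nn3-c3ccccc3)c(-c3ccccc3S(C)(=O)=O)c2C#N)cc1` carries methylsulfonyl in place of methyl on an aromatic carbon, ortho to a large group (methylsulfonyl in place of methyl on an aromatic carbon). The measured steps that bear on this change are exchanges on the same aromatic carbon: a step that the two limits leave unreadable from compound 1 to compound 3, a step that the two limits leave unreadable from compound 2 to compound 3 and a step that the two limits leave unreadable from compound 1 to compound 2. None of them has a readable size, so no measured step size can be carried over to the new group. The expectation therefore rests only on compound 1, compound 2 and compound 3 all sitting at the limit of > 20000 nM in this assay, at which 3 of the 3 values shown sit, with cyano, bromo and methyl at this place.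

The estimated step is a number no higher from compound 3 to compound 4 (the limit leaves the size open), so no change beyond the scatter is expected, and a further report of the limit is the likeliest outcome. For compound 4 the expected value is 20000 nM, with an estimated range of 10000 nM to 40000 nM.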

Compound 4, half-maximal effective concentration: > 20000 nM
Compound 4: only a limit was reported (the forecaster's own chance of this, stated with the estimate: 85%); the middle value lies on the limit itself.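

In this assay compound 4 gives > 20000 nM, a limit and not a number. Among these compounds, no step from compound 1, compound 2 or compound 3 to compound 4 can be read, since both ends of each are limits. The compounds shown leave open at what concentration any of them has an effect, and whether cyano, bromo, methyl and methylsulfonyl differ at this place, with the series standing at: the limit of > 20000 nM in this assay, at which 4 of the 4 values shown sit.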